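Removing chloro from compound 3: working notes

A few compounds are considered here, and "the series" means these few. Any claim that something is new, unique, unknown or untested is made for them only; others in the source may bear on it.

Measured in a functional assay on A549 cells (Homo sapiens) for cytotoxicity, read by MTT assay, with a stated time of 48 h; on this read-out higher numbers stand for weaker inhibition and lower numbers for stronger inhibition:
- compound 1 `Cc1[nH]c2ccc([N+](=O)[O-])cc2c1C1(c2c(C)[nH]c3ccc([N+](=O)[O-])cc23)C(=O)Nc2ccccc21`: 890 nM
- compound 2 `O=C1Nc2ccccc2C1(c1c(-c2ccccc2)[nH]c2ccccc12)c1c(-c2ccccc2)[nH]c2ccccc12`: 8910 nM
- compound 3 `O=C1Nc2ccc(Cl)cc2C1(c1c[nH]c2ccc(Br)cc12)c1c[nH]c2ccc(Br)cc12`: > 100000 nM (a limit of the assay)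

Compound 3 stands at > 100000 nM in this assay, and this is a limit and not a number. Compound 1 and compound 2 both return numbers, but each differs from compound 3 in more than one place.

Compound 4 `O=C1Nc2ccccc2C1(c1c[nH]c2ccc(Br)cc12)c1c[nH]c2ccc(Br)cc12` differs from compound 3 by hydrogen in place of chloro on an aromatic carbon. Among the compounds with values here, no measured pair isolates this change, so the expectation is weakly anchored. A modest move towards stronger inhibition is expected, though compound 4 may still reach the limit of the assay. The expected step is an at least 3.3-fold lower number from compound 3 to compound 4 (0.52 log units; beyond the scatter). For compound 4 the estimated value is 30000 nM, with an expected range of 5000 nM to 100000 nM.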

Compound 4, half-maximal inhibitory concentration: 960 nM
The estimate for compound 4 lay 31-fold (1.49 log units) above the measured number; the measured number lies below the stated range.
By their numbers in this assay, from the lowest: compounds 1 and 4 (each within the scatter of the next); then compound 2. At a limit, above all of these: compound 3.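

In this assay, hydrogen in place of chloro on an aromatic carbon gives an at least 100-fold lower number from compound 3 to compound 4 (2.01 log units; beyond the scatter), so this single place separates a compound at the limit from one that returns a number. Compound 3 holds a limit and not a number, so the step is a bound and its full size cannot be read: the limit of > 100000 nM in this assay, at which 1 of the 4 values shown sits. Compound 1 and compound 2 differ from compound 3 in more than one place and said nothing about this position, whereas the pair here ties the change to it alone.

Only chloro and hydrogen are shown at this place, so it remains open whether an amine, a methoxy group or a carboxylic acid there would give a number or a limit. Also open, on these data alone, is whether chloro at this place would have a similar effect on the core of compound 1 or compound 2.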